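Swapping thiophen-3-yl for phenyl on a shared riboside core

The source may report more compounds than this note shows. Statements on the series, on what has been measured and on what is new or still open speak of the compounds shown alone.

For the measured compounds named here, compound 1 `COc1ncnc2c1c(-c1ccsc1)cn2[C@@H]1O[C@H](CO)[C@@H](O)[C@H]1O` is the only member of this set to give a number in a functional assay on CEM-DNR-bulk cells (Homo sapiens), read by MTT assay, with a stated time of 72 h; a higher number here means a weaker inhibitor, a lower number a stronger inhibitor: compound 1 gives 7640 nM. Compound 2 `CN(C)c1ncnc2c1c(-c1ccsc1)cn2[C@@H]1O[C@H](CO)[C@@H](O)[C@H]1O` reaches only a limit, > 20000 nM. Compound 3 `COc1nc(N)nc2c1c(-c1ccsc1)cn2[C@@H]1O[C@H](CO)[C@@H](O)[C@H]1O` likewise reaches only a limit, > 20000 nM. The two measured steps, an at least 2.6-fold higher number from compound 1 to compound 2 (0.41 log units; beyond the scatter) and an at least 2.6-fold higher number from compound 1 to compound 3 (0.41 log units; beyond the scatter), both end at the limit of > 20000 nM in this assay, at which 2 of the 3 values shown sit. Compound 4 `COc1ncnc2c1c(-c1ccccc1)cn2[C@@H]1O[C@H](CO)[C@@H](O)[C@H]1O` differs from compound 1 at a different place: phenyl in place of thiophen-3-yl on an aromatic carbon. Neither measured step touches this position, so nothing here bears directly on the change. Compound 4 is therefore expected to sit close to compound 1, within the scatter, with the estimate 8000 nM (range 2500 nM to 20000 nM), a step of a 1.0-fold higher number from compound 1 to compound 4 (0.02 log units; within the scatter).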

Compound 4, half-maximal inhibitory concentration: > 20000 nM
Compound 4 ended at the assay's limit (the forecaster's own chance of this, stated with the estimate: 30%); middle value at least 2.5-fold (0.39 log units) from the limit.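

In this assay, this place on the aromatic carbon is not indifferent to the ring it carries: phenyl in place of thiophen-3-yl gives an at least 2.6-fold higher number from compound 1 to compound 4 (0.41 log units; beyond the scatter). The earlier steps shown here changed other places on the shared core, and this one shows that a change at this place alone also loses the measured number of compound 1. The step ends at a limit and not at a number, so its full size stays unknown: the limit of > 20000 nM in this assay, at which 3 of the 4 values shown sit.

Going by these compounds, whether furan-3-yl or an ethyl chain at this place would keep a number like that of compound 1 stays open.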